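The source may hold more compounds than are shown below. What is called first, only, known or untested is meant among the compounds shown, and "the series" means these compounds.

Measured compounds:
compound 1, `CO[C@]1(C)/C=C/C(=O)/C(CO)=C\C[C@](C)(CCC=C(C)C)/C=C/[C@H]1OC(=O)C=C(C)C`, 15800 nM
compound 2, `CC(C)=CCC[C@]1(C)/C=C/[C@@H](OC(=O)C=C(C)C)[C@](C)(O)/C=C/C(=O)/C(CCl)=C\C1`, 840 nM

In a functional assay on SMMC-7721 cells (Homo sapiens) for antiproliferative activity, read by MTT assay, with a stated time of 48 h (on this read-out higher numbers stand for weaker inhibition and lower numbers for stronger inhibition), compound 2 stands lowest of the two numbers shown; its nearest neighbour is compound 1, whose number is higher by a margin beyond the scatter, so compound 2 is the stronger inhibitor of the pair. Compound 3, `CC(C)=CCC[C@]1(C)/C=C/[C@@H](OC(=O)C=C(C)C)[C@](C)(O)/C=C/C(=O)/C(Cn2cc(CO)nn2)=C\C1`, has not yet been measured. It differs from compound 2 in one place: 4-(hydroxymethyl)-1H-1,2,3-triazol-1-yl in place of chloro on a saturated chain carbon bound to a double-bonded ring carbon. For the measured compounds named here, no step between measured compounds covers this change, so the expectation rests on the two values alone. Since compound 2 gives 840 nM and compound 1 gives 15800 nM, a change of this size on a saturated chain carbon bound to a double-bonded ring carbon is expected to move the number upward by a moderate step, a 3.0-fold higher number from compound 2 to compound 3 (0.47 log units; beyond the scatter), rather than to leave it within the scatter. Compound 3 is accordingly estimated at 2500 nM, with a range from 800 nM to 8000 nM.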

Compound 3, half-maximal inhibitory concentration: 3560 nM
Beside the measured number, compound 3's estimate is 1.4-fold (0.15 log units) below it, and the stated range covers the measured number.
By their numbers in this assay, from the lowest: compound 2; then compound 3; then compound 1.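

In this assay, putting 4-(hydroxymethyl)-1H-1,2,3-triazol-1-yl in place of chloro on a saturated chain carbon bound to a double-bonded ring carbon gives a 4.2-fold higher number from compound 2 to compound 3 (0.63 log units; beyond the scatter) and so costs inhibition beyond the scatter. For the compounds shown here, this is the first change at this place that can be read on its own, since compound 1 differs from compound 2 in more than one place. It shows that the place accepts a five-membered aromatic ring of 7 heavy atoms in exchange for a single chlorine at only a modest loss, although nothing at hand explains that loss.

The compounds shown leave open whether the ring or its hydroxymethyl accounts for the step, as no plain 1H-1,2,3-triazol-1-yl stands among them. They also do not tell how an amine or a carboxylic acid would read at this place.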